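Series notes: from compound 1 to compound 3

A few compounds are considered here, and "the series" means these few. Any claim that something is new, unique, unknown or untested is made for them only; others in the source may bear on it.

Of the compounds shown here, two have been measured in a functional assay on PANC-1 cells (Homo sapiens) for antiproliferative activity, read by MTT assay, with a stated time of 24 h; a higher number here means a weaker inhibitor, a lower number a stronger inhibitor. Compound 1, `CC(=O)Oc1ccccc1C(=O)NCC[Se]C#N`, gives 12100 nM in this assay. Compound 2, `CC(=O)Oc1ccccc1C(=O)[Se]CC[Se]C(=O)c1ccccc1OC(C)=O`, gives 33400 nM in this assay. Of the two numbers, compound 1 stands at the lowest; the nearest is compound 2, whose number is higher by a margin that lies beyond the usual scatter. For the measured compounds named here, no pair of measured compounds differs in a single place, so no measured step exists for comparison.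

Compound 3, `CC(=O)Oc1ccccc1C(=O)NCCSC#N`, is the next compound to be measured in this assay. It differs from compound 1 as follows: a group of 3 heavy atoms (1 carbon, 1 nitrogen, 1 sulfur; no ring) in place of a group of 3 heavy atoms (1 carbon, 1 nitrogen, 1 selenium; no ring), on a saturated chain carbon, two bonds along the chain from an amide-type nitrogen. Going by the values given here, nothing among the measured compounds shows what this exchange does to the number; compound 2 is not a single-place neighbour of either compound. The expectation is a modest weakening, a step of about a 2.1-fold higher number from compound 1 to compound 3 (0.32 log units; beyond the scatter), since the arrangement present in compound 1 gave the lowest number seen so far at 12100 nM. Compound 3 is therefore estimated at 25000 nM in this assay, with a likely range from 10000 nM to 60000 nM.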

Compound 3, half-maximal inhibitory concentration: > 50000 nM
Compound 3 was reported as a limit; the forecaster's own chance of this, stated with the estimate: 15%; middle value at least 2.0-fold (0.30 log units) from the limit.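

For the compounds shown here, the exchange of the selenium-bearing group of compound 1 for cyanosulfanyl, on a saturated chain carbon, two bonds along the chain from an amide-type nitrogen, provides the first single-place comparison, and in this assay it gives an at least 4.1-fold higher number from compound 1 to compound 3 (0.61 log units; beyond the scatter). Compound 3 gives > 50000 nM, which is a limit of the assay and not a number. This pair therefore shows that the selenium atom cannot be exchanged for sulfur at this position without a loss beyond the scatter, while the full size of the step stays unknown on its upper side: the limit of > 50000 nM in this assay, at which 1 of the 3 values shown sits.

Going by these compounds alone, it remains open whether the same exchange would cost as much with a longer chain between the amide-type nitrogen and the selenium or sulfur atom, as this pair offers only one chain length and one core. It is equally open what an amine or a carboxylic acid in place of the nitrile would do, and compound 2 still has no single-place neighbour among the compounds shown.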